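The source may report more compounds than this note shows. Statements on the series, on what has been measured and on what is new or still open speak of the compounds shown alone.

Measured so far in a functional assay on HT-29 cells (Homo sapiens) for cytotoxicity, read by MTT assay, with a stated time of 72 h; a lower number here means a stronger inhibitor, a higher number a weaker inhibitor 
- compound 1 `NCCCNc1c(C(=O)NCc2ccc(F)cc2)nc(Br)c2cccnc12` gives "not determined" (no result reported) 
- compound 2 `CN(C)CCCNc1c(C(=O)NCc2ccc(F)cc2)nc(Br)c2cccnc12` gives 6000 nM 

Among the measured compounds shown here, compound 2 holds the only number so far, and compound 1 has no result, so no ranking can be drawn and no measured step is available. The next compound to be read in this assay is compound 3 `O=C(NCCCNc1c(C(=O)NCc2ccc(F)cc2)nc(Br)c2cccnc12)c1ccccc1` which keeps the shared core and differs only at the end of the chain. The change is benzamido in place of dimethylamino on a saturated chain carbon, three bonds along the chain from a nitrogen on an aromatic ring and it lies on a saturated chain carbon, three bonds along the chain from a nitrogen on an aromatic ring. The entering benzamido group brings one six-membered aromatic ring of carbon only.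

For the measured compounds named here, with no measured step to scale against, the expectation rests on the structural change and on the single value of compound 2 at 6000 nM as the starting point. The estimated move is a 1.7-fold higher number from compound 2 to compound 3 (0.22 log units; within the scatter) in the direction of a weaker inhibitor, modest in size and only loosely supported. For compound 3 the expected value is 10000 nM with an estimated range from 3000 nM to 40000 nM as the working figures.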

Compound 3, half-maximal inhibitory concentration: > 10000 nM
Compound 3 gave a limit, no number; the forecaster's own chance of this, stated with the estimate: 25%; the middle value lies on the limit itself.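

In this assay compound 3 gives > 10000 nM, which is a limit of the assay and not a number. Benzamido in place of dimethylamino on a saturated chain carbon, three bonds along the chain from a nitrogen on an aromatic ring, gives an at least 1.6-fold higher number from compound 2 to compound 3 (0.22 log units; that floor lies within the scatter), the first step that can be read at this position; it is only a floor, and the true size of the step stays unknown. The result shows no gain from exchanging dimethylamino for benzamido at this place, and that statement rests on a single reading at the limit: the limit of > 10000 nM in this assay, at which 1 of the 3 values shown sits.

The compounds shown leave open whether the aromatic ring of the benzamido group or the amide itself carries this step, a question that an acetamido group at the same place would address. Also open, going by these compounds, is how a carboxylic acid at the chain end or a longer chain would read in this assay, and the step to compound 1 cannot be read.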